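Working notes: aryl change from compound 2 to compound 3

The source may report more compounds than this note shows. Statements on the series, on what has been measured and on what is new or still open speak of the compounds shown alone.

- Compound 1 `Cc1cccc(/C=N/Nc2ncc3c(n2)n(C2CCCC2)c(=O)c(=O)n3C)c1`: > 100000 nM (a limit of the assay)
- Compound 2 `Cc1cc(C)c(/C=N/Nc2ncc3c(n2)n(C2CCCC2)c(=O)c(=O)n3C)c(C)c1`: 7920 nM

Both compounds were tested in a functional assay on HCT-116 cells (Homo sapiens) for antiproliferative activity, read by MTT assay; on this read-out lower numbers stand for stronger inhibition and higher numbers for weaker inhibition. Among the compounds with values here, compound 2 holds the only actual number so far, 7920 nM. Compound 1 gives > 100000 nM, which is a limit and not a number.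

The next compound is compound 3 `Cc1ccc(/C=N/Nc2ncc3c(n2)n(C2CCCC2)c(=O)c(=O)n3C)cc1C`, with the change (3,4-dimethylphenyl in place of 2,4,6-trimethylphenyl on a carbon with a double bond to nitrogen). By name, the entering 3,4-dimethylphenyl stands closer to the 3-methylphenyl of compound 1 than to the group it replaces. Within the data shown here, the one measured step bearing on this change is large and beyond the scatter: an at least 12-fold lower number from compound 1 to compound 2 (1.10 log units; beyond the scatter). On that step, a sizeable move to a higher number, meaning weaker inhibition, is expected in this assay. The expected change is a 5.1-fold higher number from compound 2 to compound 3 (0.70 log units; beyond the scatter). For compound 3 the estimated value is 40000 nM, with an expected range of 10000 nM to 120000 nM.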

Compound 3, half-maximal inhibitory concentration: 62900 nM
Compound 3: the middle estimate sits 1.6-fold (0.20 log units) below what was measured, and the stated range covers the measured number.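

Notes on the aryl group on a carbon with a double bond to nitrogen: in this assay, 3,4-dimethylphenyl does not retain the result of 2,4,6-trimethylphenyl, with a 7.9-fold higher number from compound 2 to compound 3 (0.90 log units; beyond the scatter), so a second methyl on the aryl group is not enough on its own to match compound 2. Compound 2 remains the strongest of the three, and the steps to it from both other compounds lie beyond the scatter. On these data alone, the single added methyl gives an at least 1.5-fold lower number from compound 1 to compound 3 (0.20 log units; that floor lies within the scatter), a floor within the scatter, so the true size of this step stays unknown: the limit of > 100000 nM in this assay, at which 1 of the 3 values shown sits.

The compounds shown do not separate the number of methyl groups from their arrangement on the aryl ring. As far as these compounds go, the response to a methoxy group or an amine in place of these methyl groups also remains open.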